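From 4-chlorophenyl to 3,5-dimethylphenyl on a sulfur

A few compounds are considered here, and "the series" means these few. Any claim that something is new, unique, unknown or untested is made for them only; others in the source may bear on it.

compound 1 `Nc1ccccc1NC(=O)c1ccc(CSc2ccc(Br)cc2)cc1`: 38.2%
compound 2 `Nc1ccccc1NC(=O)c1ccc(CSc2ccc(F)cc2)cc1`: 79.3%
compound 3 `Nc1ccccc1NC(=O)c1ccc(CSc2ccc(Cl)cc2)cc1`: 51.4%

All three values come from a functional assay on HeLa cells (Homo sapiens) for inhibition, read by CCK-8 assay, with a stated time of 72 h, tested at 8 uM; on this read-out lower numbers stand for less inhibition of growth and higher numbers for more inhibition of growth at the one concentration tested. Compound 3 is the second highest of the three, below compound 2 and above compound 1, with both gaps beyond the scatter. Compound 4 `Cc1cc(C)cc(SCc2ccc(C(=O)Nc3ccccc3N)cc2)c1` differs from compound 3 by one change, (3,5-dimethylphenyl in place of 4-chlorophenyl on a sulfur), which is 3,5-dimethylphenyl in place of 4-chlorophenyl on a sulfur.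

Among the measured compounds shown here, three measured steps bear on this change, and each exchanges one halogen for another on that same aromatic group. The large one is a number 41.1 percentage points higher from compound 1 to compound 2 (beyond the scatter), with fluoro in place of bromo. The modest ones are a number 13.2 percentage points higher from compound 1 to compound 3 (beyond the scatter), with chloro in place of bromo, and a number 27.9 percentage points lower from compound 2 to compound 3 (beyond the scatter), with chloro in place of fluoro. These steps show that the read-out can shift widely with the group on the sulfur. None of them involves methyl groups, so the data give no firm direction for the new group. A step of modest size either way remains possible, with a slight lean towards lower numbers. The expected outcome is a number 6.4 percentage points lower from compound 3 to compound 4 (within the scatter), and this estimate carries wide uncertainty. For compound 4 the estimated value is 45%, expected to fall between 22% and 68%.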

Compound 4, percent growth inhibition at one concentration: 78.9%
The estimate for compound 4 lay 33.9 percentage points below the measured number, outside the stated range (above it).
By their numbers in this assay, from the lowest: compound 1; then compound 3; then compounds 4 and 2 (each within the scatter of the next).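

In this assay the group on the sulfur needs no halogen to reach a high number: 3,5-dimethylphenyl, which carries two methyl groups and no chlorine, lifts the read-out well clear of the 4-chlorophenyl compound (a number 27.5 percentage points higher from compound 3 to compound 4 (beyond the scatter)) and further still clear of the 4-bromophenyl compound (a number 40.7 percentage points higher from compound 1 to compound 4 (beyond the scatter)). Against 4-fluorophenyl the same group makes no difference that can be told apart (a number 0.4 percentage points lower from compound 2 to compound 4 (within the scatter)), so two quite differently substituted phenyl groups now stand level, and both stand beyond the scatter above the chloro and bromo compounds. Nothing given here explains why these groups rank as they do.

On these data alone, it remains open whether a single methyl group on the phenyl would hold the number, or whether the two methyl groups are both needed. Also open, as far as these compounds go, is how the read-out would respond to a methoxy group, an amine or a carboxylic acid on that ring, and whether the level standing of these two compounds would persist at other concentrations than the one used in this assay.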